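Swapping the sulfonyl aryl group in a cyclic sulfonamide

The source may report more compounds than this note shows. Statements on the series, on what has been measured and on what is new or still open speak of the compounds shown alone.

Measured so far:
Compound 1, `C=C(CC)C(=O)c1ccc(OCC(=O)NCCNS(=O)(=O)c2ccc(OC)cc2OC)c(Cl)c1Cl`, gives 2790 nM.
Compound 2, `C=C(CC)C(=O)c1ccc(OCC(=O)NCCNS(=O)(=O)c2cc(Cl)ccc2OC)c(Cl)c1Cl`, gives 1600 nM.
Compound 3, `C=C(CC)C(=O)c1ccc(OCC(=O)N2CCN(S(=O)(=O)c3ccc(OC)cc3OC)CC2)c(Cl)c1Cl`, gives 3190 nM.

These values come from a functional assay on HL-60 cells (Homo sapiens) for cytotoxicity, read by luminescence; on this read-out higher numbers stand for weaker inhibition and lower numbers for stronger inhibition. Compound 1 and compound 2 share a core and differ in one place: 5-chloro-2-methoxyphenyl in place of 2,4-dimethoxyphenyl on a sulfonyl sulfur. That change gave a 1.7-fold lower number from compound 1 to compound 2 (0.24 log units; within the scatter), a step that does not rise above the usual scatter of repeated measurements.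

Compound 3 carries a different core; the difference between the core of compound 1 and the core of compound 3 is not broken down here. Compound 3 and compound 1 give numbers close to each other in this assay, and compound 3 and compound 2 likewise stay within the scatter of each other, so no order among the three can be read from these data.

Compound 4, `C=C(CC)C(=O)c1ccc(OCC(=O)N2CCN(S(=O)(=O)c3cc(Cl)ccc3OC)CC2)c(Cl)c1Cl`, has not yet been measured. It differs from compound 3 by 5-chloro-2-methoxyphenyl in place of 2,4-dimethoxyphenyl on a sulfonyl sulfur. Going by the values given here, this is the same kind of change as the one from compound 1 to compound 2, though not the same: there the sulfonyl sulfur sat on a sulfonamide nitrogen, here it sits on a sulfonamide nitrogen in a ring.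

For compound 4 in this assay a step like the earlier one is expected, a 1.7-fold lower number from compound 3 to compound 4 (0.23 log units; within the scatter), because the same kind of swap gave a 1.7-fold lower number from compound 1 to compound 2 (0.24 log units; within the scatter). Compound 4 is therefore estimated at 1900 nM, with a likely range from 900 nM to 4000 nM.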

Compound 4, half-maximal inhibitory concentration: 1410 nM
Compound 4: middle estimate off by 1.3-fold (0.13 log units), on the high side, within the range that was stated.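

In this assay, putting 5-chloro-2-methoxyphenyl in place of 2,4-dimethoxyphenyl on a sulfonyl sulfur attached to a sulfonamide nitrogen in a ring gave a 2.3-fold lower number from compound 3 to compound 4 (0.35 log units; beyond the scatter), a modest step in the direction of stronger inhibition. Set beside the earlier step, this result shows that the swap behaves alike on the two cores, with no difference that can be told apart from ordinary measurement noise: the same change on two cores in this assay, a 1.7-fold lower number (0.24 log units; within the scatter) from compound 1 to compound 2 and a 2.3-fold lower number (0.35 log units; beyond the scatter) from compound 3 to compound 4, 1.3-fold (0.11 log units) apart, within the scatter of two such steps. Going by these compounds alone, it does not show that the swap has a firmly established effect on both cores, since only the step on the core of compound 3 rises above the scatter, and two cores say nothing about how the swap would behave on a third one, or why the numbers move at all.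

The compounds shown leave open which part of the new aryl group matters, for instance whether a plain 2-methoxyphenyl, or a bromine or a nitrile in place of the chlorine, would give a similar number. They also leave open whether the swap would carry over to a core with a longer chain in place of the open linker of compound 1.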